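Isopropylamino for Isopropyl on a Bile Acid Receptor Series

The compounds below may be only part of what the source reports. "The series", "measured", "known", "first", "only" and "open" are said of these compounds alone.

Of the compounds shown here, three built around a shared arrangement have been tested in an assay on isolated protein with Bile acid receptor (Homo sapiens) as the target; a higher number here means that more compound is needed for the effect, a lower number that less compound is needed. Compound 1 `COC(=O)/C=C/c1cccc(N(Cc2ccc(/C=C/c3cccc(C(F)(F)F)c3)cc2)C(=O)C(C)C)c1` gives 267 nM in this assay. Compound 2 `COC(=O)/C=C/c1cccc(N(Cc2ccc(/C=C/c3cccc(C(F)(F)F)c3)cc2)C(=O)NC(C)C)c1` differs from compound 1 in one place only, (isopropylamino in place of isopropyl on a carbonyl carbon), and in this assay compound 2 gives 932 nM. That single exchange produced a 3.5-fold higher number from compound 1 to compound 2 (0.54 log units; beyond the scatter). Compound 3 `COC(=O)/C=C/c1cccc(N(Cc2ccc(-c3ccc(N(C)C)cc3)cc2)C(=O)C(C)C)c1` carries a different core; how it differs from compound 1 is counted as 4-(dimethylamino)phenyl in place of 2-(3-(trifluoromethyl)phenyl)ethenyl on an aromatic carbon. In this assay compound 3 gives 57 nM, and the step is a 4.7-fold lower number from compound 1 to compound 3 (0.67 log units; beyond the scatter). Of the three measured compounds, compound 3 has the lowest number, and its steps to each of the other two lie beyond the scatter.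

Compound 4 `COC(=O)/C=C/c1cccc(N(Cc2ccc(-c3ccc(N(C)C)cc3)cc2)C(=O)NC(C)C)c1` has not been measured. It stands to compound 3 as compound 2 stands to compound 1: the difference is isopropylamino in place of isopropyl on a carbonyl carbon, and the surroundings of the place are described in the same words, so this is the same change made on the other core. The change has been seen only once among these compounds, so how faithfully it carries over is not known. The step expected in this assay is a 3.5-fold higher number from compound 3 to compound 4 (0.55 log units; beyond the scatter), resting on the earlier 3.5-fold higher number from compound 1 to compound 2 (0.54 log units; beyond the scatter). Compound 4 is therefore expected to give about 200 nM in this assay, with 80 nM to 500 nM as the likely range.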

Compound 4, half-maximal effective concentration: 162 nM
Estimate against measurement, compound 4: 1.2-fold (0.09 log units) above; measured number inside the range.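

In this assay, putting isopropylamino in place of isopropyl on the carbonyl carbon had the same outcome on the second core as on the first, giving a 2.8-fold higher number from compound 3 to compound 4 (0.45 log units; beyond the scatter), and the two steps agree in size: the same change on two cores in this assay, a 3.5-fold higher number (0.54 log units; beyond the scatter) from compound 1 to compound 2 and a 2.8-fold higher number (0.45 log units; beyond the scatter) from compound 3 to compound 4, 1.2-fold (0.09 log units) apart, within the scatter of two such steps. The other exchange, 4-(dimethylamino)phenyl in place of 2-(3-(trifluoromethyl)phenyl)ethenyl, also held up when the isopropylamino group was present, giving a 5.8-fold lower number from compound 2 to compound 4 (0.76 log units; beyond the scatter), so in these four compounds each change kept its size whichever form of the other place it met: the same change on two cores in this assay, a 4.7-fold lower number (0.67 log units; beyond the scatter) from compound 1 to compound 3 and a 5.8-fold lower number (0.76 log units; beyond the scatter) from compound 2 to compound 4, 1.2-fold (0.09 log units) apart, within the scatter of two such steps. This is one agreement between two cores, resting on a single pair of compounds for each step, so it does not show that the change would carry over to any further core, and it says nothing about why the number moves.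

The compounds shown leave open whether a smaller or a longer chain on the carbonyl carbon, such as methylamino or n-butylamino, would follow the same course as isopropylamino. They also leave open whether these steps would keep their size if a carboxylic acid stood in place of the methyl ester.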